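The source may report more compounds than this note shows. Statements on the series, on what has been measured and on what is new or still open speak of the compounds shown alone.

Measured compounds:
compound 1, `CCCCC(C)(C)[C@H](O)/C=C/[C@H]1CCC(=O)N1CCSc1nc(C(=O)O)cs1`: 4.2 nM
compound 2, `CC(C)(C)CCC1([C@H](O)/C=C/[C@H]2COC(=O)N2CCSc2nc(C(=O)O)cs2)CCC1`: 4710 nM

For the measured compounds named here, in an assay on isolated protein for agonist activity at prostaglandin E2 receptor EP4 subtype (Homo sapiens) (a higher number here means that more compound is needed for the effect, a lower number that less compound is needed), compound 2 gives 4710 nM, the higher of the two numbers known so far. Going by the values given here, its only measured companion is compound 1, which in this assay gives 4.2 nM, a far lower number, a gap well beyond the scatter. Among the compounds with values here, the two compounds differ in more than one place, so what the gap shows is only that compound 2 is the weaker of the pair, not which part of its structure accounts for that.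

Compound 3, `O=C(O)c1csc(SCCN2C(=O)OC[C@@H]2/C=C/[C@@H](O)C2(CCCCF)CCC2)n1`, has not yet been measured in this assay. It differs from compound 2 in one place: 2-fluoroethyl in place of tert-butyl on a saturated chain carbon, two bonds along the chain from a saturated ring carbon. Within the data shown here, no measured pair shows how this exchange alone moves the read-out, so the expected step of a 1.9-fold lower number from compound 2 to compound 3 (0.28 log units; within the scatter) rests on the single starting point alone and is expected to be small, if anything a slight move toward a lower number, not clearly beyond the scatter. Compound 3 is therefore expected to give about 2500 nM in this assay, within a range from 600 nM to 10000 nM.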

Compound 3, half-maximal effective concentration: 195 nM
For compound 3 the middle estimate is 13-fold (1.11 log units) above the measured one; measured number outside the range, below it.
By their numbers in this assay, from the lowest: compound 1; then compound 3; then compound 2.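

In this assay, the exchange of tert-butyl for 2-fluoroethyl on a saturated chain carbon, two bonds along the chain from a saturated ring carbon, gives a 24-fold lower number from compound 2 to compound 3 (1.38 log units; beyond the scatter). The earlier pair differed in more than one place and could tie its gap to no single site, whereas this pair shows that the outer end of this chain can by itself move the read-out strongly, with the rest of the structure unchanged. No measurement bears on why the read-out moves this far.

This one exchange removes the branched end and brings in fluorine together, and the pair cannot separate the two. Going by these compounds, an ethyl group, a 2-hydroxyethyl group or a longer chain at this place would show which of them goes with the step, and whether the same exchange moves the read-out in the same way on the core of compound 1 also remains open.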